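Replacing the pyrazolyl sulfone of compound 2 with a hydroxypiperidinyl sulfonamide

This account rests on a few compounds, and the source may have more. Where it says the series, first, only, none or still open, it means among the compounds named here.

Compound 2 `CCCn1cc(S(=O)(=O)c2ccc(CNC(=O)N3Cc4ccncc4C3)cc2)cn1` gives 7.3 nM in a functional assay on A2780 cells (Homo sapiens) for cytotoxicity, read by sulforhodamine B assay, with a stated time of 72 h (on this read-out higher numbers stand for weaker inhibition and lower numbers for stronger inhibition), the second highest of the three numbers measured: compound 1 `O=C(NCc1ccc(S(=O)(=O)c2cccc(C(F)(F)F)c2)cc1)N1Cc2ccncc2C1` gives 2.7 nM, and compound 3 `O=C(NCc1ccc(S(=O)(=O)C2CCOCC2)cc1)N1Cc2ccncc2C1` gives 35 nM. Compound 4 `O=C(NCc1ccc(S(=O)(=O)N2CCC[C@H](O)C2)cc1)N1Cc2ccncc2C1` carries this change: 3-hydroxypiperidin-1-yl in place of 1-propyl-1H-pyrazol-4-yl on a sulfonyl sulfur. Among the measured compounds shown here, the steps that bear on it both swap an aromatic group on the sulfonyl sulfur for a saturated six-membered ring: a 4.8-fold higher number from compound 2 to compound 3 (0.68 log units; beyond the scatter) and a 13-fold higher number from compound 1 to compound 3 (1.11 log units; beyond the scatter). Since compound 3 is the nearest measured neighbour with a saturated ring at this position, compound 4 is expected to sit near it, a weakening step a 4.1-fold higher number from compound 2 to compound 4 (0.61 log units; beyond the scatter) from compound 2. Compound 4 is therefore estimated at 30 nM, with a range from 10 nM to 100 nM.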

Compound 4, half-maximal inhibitory concentration: 150 nM
Compound 4: the middle estimate sits 5.0-fold (0.70 log units) below what was measured; measured number above the stated range.
By their numbers in this assay, from the lowest: compound 1; then compound 2; then compound 3; then compound 4.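

In this assay the 3-hydroxypiperidin-1-yl group costs far more than the earlier saturated ring suggested, with a 21-fold higher number from compound 2 to compound 4 (1.31 log units; beyond the scatter) and a 56-fold higher number from compound 1 to compound 4 (1.74 log units; beyond the scatter). A further a 4.3-fold higher number from compound 3 to compound 4 (0.63 log units; beyond the scatter) shows that saturated six-membered rings on this sulfonyl sulfur are not interchangeable. No supporting measurement bears on this difference. On these data alone, whether the loss follows the hydroxyl or the piperidine ring stays open, and a plain piperidin-1-yl or a morpholin-4-yl group on the sulfonyl sulfur would bear on that question.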